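A Second Chloro Group on a Rearranged Core

The source may report more compounds than this note shows. Statements on the series, on what has been measured and on what is new or still open speak of the compounds shown alone.

Three measured compounds and one unmeasured compound make up this small set. Compound 1 `ClCc1cccc(Cn2cnc3c(Cl)ncnc32)c1` was tested in a functional assay on SNB-75 cells (Homo sapiens) for cytotoxicity, read by sulforhodamine B assay, with a stated time of 48 h (on this read-out higher numbers stand for lower toxicity in this test and lower numbers for higher toxicity in this test), where compound 1 gives 10000 nM. Compound 2 `ClCc1cccc(Cn2cnc3c(Cl)nc(Cl)nc32)c1` differs from compound 1 by one change, (chloro in place of hydrogen on an aromatic carbon). In this assay compound 2 gives 7410 nM, and the step is a 1.3-fold lower number from compound 1 to compound 2 (0.13 log units; within the scatter). Compound 3 `ClCc1ccccc1Cn1cnc2ncnc(Cl)c21` is built from the same atoms as compound 1, joined differently; the difference between the two cores is not broken down here. In this assay compound 3 gives 63100 nM, the highest of the three numbers and beyond the scatter from both compound 1 and compound 2. Compound 4 `ClCc1ccccc1Cn1cnc2nc(Cl)nc(Cl)c21` has not yet been measured. For the measured compounds named here, it differs from compound 3 by chloro in place of hydrogen on an aromatic carbon, which is the same change as the one from compound 1 to compound 2, placed in the same surroundings. Going by the values given here, because the first instance of this change gave a 1.3-fold lower number from compound 1 to compound 2 (0.13 log units; within the scatter), a step that stays inside the usual scatter, a similarly small step is expected for the second instance. The step expected in this assay is a 1.3-fold lower number from compound 3 to compound 4 (0.10 log units; within the scatter). In this assay compound 4 is expected to give 50000 nM, with a likely range from 20000 nM to 120000 nM. This rests on a single earlier example, so the expectation is loose, and it does not assume any further pattern beyond these compounds.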

Compound 4, concentration lethal to 50% of the cells: > 100000 nM
Compound 4: only a limit was reported; the forecaster's own chance of this, stated with the estimate: 15%; middle value at least 2.0-fold (0.30 log units) away from the limit.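

In this assay, chloro in place of hydrogen on the aromatic carbon between two ring nitrogen atoms gives an at least 1.5-fold higher number from compound 3 to compound 4 (0.19 log units; that floor lies within the scatter), whereas the same change on the core of compound 1 gives a 1.3-fold lower number from compound 1 to compound 2 (0.13 log units; within the scatter). Compound 4 gives > 100000 nM, which is a limit of the assay and not an exact number: the limit of > 100000 nM in this assay, at which 1 of the 4 values shown sits. The result therefore shows neither that the change carries over from one core to the other nor that its outcome depends on the core, since only a lowest possible size is known for the new step: the same change on two cores in this assay, a 1.3-fold lower number (0.13 log units; within the scatter) from compound 1 to compound 2 and an at least 1.5-fold higher number (0.19 log units; that floor lies within the scatter) from compound 3 to compound 4; the limit leaves it open whether they differ.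

For the compounds shown here, the actual size of the step to compound 4 stays open, and with only one pair on each core, so does how the same change would behave on any further core. Also open, from the compounds shown here alone, is whether another group on that same aromatic carbon, such as a fluoro group, a bromo group, a methoxy group or an amine, would give a step of similar size on both cores.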